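A few compounds are considered here, and "the series" means these few. Any claim that something is new, unique, unknown or untested is made for them only; others in the source may bear on it.

Compound 1 `O=C(c1ccccc1F)N1CCN(c2nc(=O)c3cc(C(F)(F)F)cc([N+](=O)[O-])c3s2)CC1` stands at the assay ceiling: in an ADME assay on Vero cells (Chlorocebus sabaeus) for cytotoxicity, read by MTT assay, with a stated time of 72 h (a higher number here means that more compound is tolerated, a lower number that less compound is tolerated), compound 1 gives > 125000 nM, which is a limit and not a number. Compound 2 `CC(C)(C)C(=O)N1CCN(c2nc(=O)c3cc(C(F)(F)F)cc([N+](=O)[O-])c3s2)CC1` gives > 125000 nM, likewise a limit. Compound 3 `CCC(C)C(=O)N1CCN(c2nc(=O)c3cc(C(F)(F)F)cc([N+](=O)[O-])c3s2)CC1` gives > 125000 nM, again a limit. Accordingly the steps read as a step that the two limits leave unreadable from compound 1 to compound 2, a step that the two limits leave unreadable from compound 1 to compound 3 and a step that the two limits leave unreadable from compound 2 to compound 3, since (the limit of > 125000 nM in this assay, at which 3 of the 3 values shown sit). Compound 4 `CCCCC(=O)N1CCN(c2nc(=O)c3cc(C(F)(F)F)cc([N+](=O)[O-])c3s2)CC1` differs from compound 1 by butyl in place of 2-fluorophenyl on a carbonyl carbon. The three measured steps, each an exchange of one acyl group for another on the same carbonyl carbon, give no readable size, so within this assay no step beyond the scatter is expected; the expected step is a step that the limit leaves unreadable from compound 1 to compound 4. Compound 4 is estimated at 150000 nM, in the range 60000 nM to 400000 nM, most probably again reported only as a limit.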

Compound 4, half-maximal cytotoxic concentration: > 125000 nM
Compound 4: a limit, no number; the forecaster's own chance of this, stated with the estimate: 85%; the middle value is on the limit's open side.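

Compound 4, like compounds 1, 2 and 3, gives only a limit, so no step among these compounds can be read: the limit of > 125000 nM in this assay, at which 4 of the 4 values shown sit.

The compounds shown leave open whether butyl, sec-butyl, tert-butyl and 2-fluorophenyl differ at all in how much compound is tolerated.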